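The compounds below may be only part of what the source reports. "The series", "measured", "known", "first", "only" and "open" are said of these compounds alone.

Compound 1 `O=C(O)c1ccc(C(=O)/C(=C\c2ccc(F)c([N+](=O)[O-])c2)SCc2ccc(F)cc2)cc1`, compound 2 `O=C(O)c1ccc(C(=O)/C(=C\c2ccc(F)c([N+](=O)[O-])c2)SCc2ccc(C(F)(F)F)cc2)cc1` and compound 3 `O=C(O)c1ccc(C(=O)/C(=C\c2ccc([N+](=O)[O-])c(F)c2)SCc2ccc(Br)cc2)cc1` share one core and have each been tested in a physicochemical assay for solubility; on this read-out higher numbers stand for higher solubility and lower numbers for lower solubility. In this assay compound 1 gives < 1000 ug/mL, which is a limit of the assay rather than a number. Compound 2 gives < 1000 ug/mL, again a limit. Compound 3 gives < 1000 ug/mL, also a limit. For the measured compounds named here, the one pair that differs in a single place gives the step that the two limits leave unreadable from compound 1 to compound 2, so its size cannot be read; the only firm evidence is the limit of < 1000 ug/mL in this assay, at which 3 of the 3 values shown sit.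

Compound 4 `O=C(O)c1ccc(C(=O)/C(=C\c2ccc(Cl)c([N+](=O)[O-])c2)SCc2ccc(Br)cc2)cc1` differs from compound 3 by 4-chloro-3-nitrophenyl in place of 3-fluoro-4-nitrophenyl on a double-bonded chain carbon bound to a double-bonded chain carbon. Going by the values given here, no measured step touches this part of the core, and the single measured step lies elsewhere and is unreadable, so no step in this assay beyond the scatter can be read from the data. Compound 3 stands at a limit, as do both other compounds, and the expected step that the limit leaves unreadable from compound 3 to compound 4 is none that the assay would resolve. For compound 4 the estimated solubility is therefore 300 ug/mL, with a range from 50 ug/mL to 1000 ug/mL, and a reported limit rather than a number is expected to be the most likely outcome.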

Compound 4, solubility: < 1000 ug/mL
Compound 4: only a limit was reported; the forecaster's own chance of this, stated with the estimate: 80%; the middle value does not contradict the limit.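

No new step can be read from compound 3 to compound 4, since each gives only a limit rather than a number in this assay: the limit of < 1000 ug/mL in this assay, at which 4 of the 4 values shown sit.

The compounds shown leave open what actual number any of them would give in this assay, and whether 4-chloro-3-nitrophenyl in place of 3-fluoro-4-nitrophenyl makes any difference there.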